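Methoxy in Place of Fluoro on the Anilide Ring

A few compounds are considered here, and "the series" means these few. Any claim that something is new, unique, unknown or untested is made for them only; others in the source may bear on it.

Compound 1 `Cc1ccccc1NC(=O)CCC(=O)OCCCCCCSc1ccc([N+](=O)[O-])c2nonc12` — 4660 nM
Compound 2 `COc1ccccc1NC(=O)CCC(=O)OCCCCCCSc1ccc([N+](=O)[O-])c2nonc12` — 2120 nM
Compound 3 `O=C(CCC(=O)OCCCCCCSc1ccc([N+](=O)[O-])c2nonc12)Nc1ccc(F)cc1` — 2500 nM

In a functional assay on 143B cells (Homo sapiens) for inhibition, read by MTT assay, with a stated time of 72 h (a lower number here means a stronger inhibitor, a higher number a weaker inhibitor), compound 3 gives 2500 nM, the second highest of the three numbers. Its nearest neighbour is compound 2, and the step of a 1.2-fold higher number from compound 2 to compound 3 (0.07 log units; within the scatter) lies within the scatter; the step of a 1.9-fold lower number from compound 1 to compound 3 (0.27 log units; within the scatter) lies within the scatter as well. Compound 4 `COc1ccc(NC(=O)CCC(=O)OCCCCCCSc2ccc([N+](=O)[O-])c3nonc23)cc1` differs from compound 3 by methoxy in place of fluoro on an aromatic carbon. Going by the values given here, the only measured step that brings in a methoxy is a 2.2-fold lower number from compound 1 to compound 2 (0.34 log units; beyond the scatter), a modest lowering beyond the scatter, though there the methoxy replaced a methyl on a 2-substituted ring rather than a fluoro. A small lowering or no step beyond the scatter is therefore expected, and the expected step of a 1.4-fold lower number from compound 3 to compound 4 (0.14 log units; within the scatter) reflects this. Compound 4 is estimated at 1800 nM, within 700 nM to 4500 nM.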

Compound 4, half-maximal inhibitory concentration: 3060 nM
Compound 4: middle estimate off by 1.7-fold (0.23 log units), on the low side, within the range that was stated.
By their numbers in this assay, from the lowest: compounds 2, 3, 4 and 1 (each within the scatter of the next, the first and the last beyond it).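

In this assay, methoxy in place of fluoro, on the aromatic carbon para to a large group, gives a step within the scatter (a 1.2-fold higher number from compound 3 to compound 4 (0.09 log units; within the scatter)). The 4-methoxyphenyl compound also stays within the scatter of both compounds with 2-substituted rings (a 1.4-fold higher number from compound 2 to compound 4 (0.16 log units; within the scatter); a 1.5-fold lower number from compound 1 to compound 4 (0.18 log units; within the scatter)), so it separates from neither. No measurement on hand offers an explanation for these results.

The compounds shown leave open whether an amine or a carboxylic acid at this ring carbon would give a step beyond the scatter.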